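This account rests on a few compounds, and the source may have more. Where it says the series, first, only, none or still open, it means among the compounds named here.

Measured compounds in a functional assay on SNB-19 cells (Homo sapiens) for inhibition, read by sulforhodamine B assay, with a stated time of 48 h, tested at 10 uM; a higher number here means more inhibition at the concentration tested (going by the name of the read-out), a lower number less inhibition:
- compound 1, `c1ccc(-c2cn3ccnc3c(-c3ccc4ncn(C5CCCCC5)c4c3)n2)cc1`: 22.9%
- compound 2, `COc1ccc(-c2cn3ccnc3c(-c3ccc4ncn(C5CCCCC5)c4c3)n2)cc1`: 68.4%
- compound 3, `c1ccc2c(-c3cn4ccnc4c(-c4ccc5ncn(C6CCCCC6)c5c4)n3)cccc2c1`: 9.08%

Compound 1 stands second highest of the three numbers; in this assay compound 1 gives 22.9%, which lies a number 45.5 percentage points higher from compound 1 to compound 2 (beyond the scatter) and a number 13.8 percentage points lower from compound 1 to compound 3 (beyond the scatter), both beyond the scatter.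

The unmeasured compound 4, `CC(=O)c1ccc(-c2cn3ccnc3c(-c3ccc4ncn(C5CCCCC5)c4c3)n2)cc1`, differs from compound 1 in one place: acetyl in place of hydrogen on an aromatic carbon. The step that bears on it most directly is a number 45.5 percentage points higher from compound 1 to compound 2 (beyond the scatter), where the read-out rises by a large amount. The step to compound 3, which changes the whole phenyl rather than adding a group to it, is less comparable and runs the other way, a number 13.8 percentage points lower from compound 1 to compound 3 (beyond the scatter). Acetyl is a different group from methoxy, so the size of its effect cannot be read off the one step; the direction, a rise, is taken from compound 2. The expected step is a number 22.1 percentage points higher from compound 1 to compound 4 (beyond the scatter), upward beyond the scatter but smaller than the step to compound 2. Compound 4 is therefore estimated to give 45%, with a range from 15% to 75%.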

Compound 4, a percentage reported as inhibition, at one concentration (the size of the read-out at that concentration, not a potency): 3.96%
Compound 4: the middle estimate sits 41 percentage points above what was measured; the whole stated range lies above it.
By their numbers in this assay, from the lowest: compounds 4 and 3 (each within the scatter of the next); then compound 1; then compound 2.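

In this assay, a group added to the phenyl, para to a large group, does not push the read-out one way: acetyl gives a number 18.9 percentage points lower from compound 1 to compound 4 (beyond the scatter), opposite in direction to the methoxy step, and exchanging one group for the other at this same place gives a number 64.4 percentage points lower from compound 2 to compound 4 (beyond the scatter), so the outcome depends on which group enters and not merely on a group being present. Within the data shown here, two different replacements of phenyl now lie within the scatter of each other, with a number 5.1 percentage points lower from compound 3 to compound 4 (within the scatter), which leaves methoxy as the only change in this set that raises the number over compound 1. Nothing measured here accounts for the gap between methoxy and acetyl at this position.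

Going by these compounds, whether an amine, a hydroxyl or a carboxylic acid at this place would fall with methoxy or with acetyl stays open. Also open, on these data alone, is whether methoxy keeps its effect elsewhere on the phenyl.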